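Little to go on for compound 3

This account rests on a few compounds, and the source may have more. Where it says the series, first, only, none or still open, it means among the compounds named here.

Compound 1 `OC[C@H]1O[C@@H](n2cnc3c(NCc4ccc(Cl)cc4Cl)ncnc32)[C@H](O)[C@@H]1O`: > 166000 nM (a limit of the assay)
Compound 2 `COc1cc(CNc2ncnc3c2ncn3[C@@H]2O[C@H](CO)[C@@H](O)[C@H]2O)cc(OC)c1`: "not determined" (no result reported)

In a functional assay on B16 cells (Mus musculus) for antiproliferative activity, with a stated time of 72 h (a higher number here means a weaker inhibitor, a lower number a stronger inhibitor), compound 2 has no number, and its entry reads "not determined" (no result reported). Compound 1 gives only a limit of the assay, > 166000 nM. Within the data shown here, compound 2 therefore cannot be placed on a scale, and no measured step exists to serve as a guide.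

The change 2,3,4-trifluorophenyl in place of 3,5-dimethoxyphenyl on a saturated chain carbon bound to a nitrogen on an aromatic ring puts 2,3,4-trifluorophenyl in place of 3,5-dimethoxyphenyl on a saturated chain carbon bound to a nitrogen on an aromatic ring. It leads to compound 3 `OC[C@H]1O[C@@H](n2cnc3c(NCc4ccc(F)c(F)c4F)ncnc32)[C@H](O)[C@@H]1O`, which is not yet measured. With no number for compound 2, the step expected in this assay is none beyond the scatter, in either direction. This expectation of weak activity rests on compound 1 alone, whose limit is > 166000 nM. For compound 3 the expected value is 170000 nM, with an estimated range of 40000 nM to 400000 nM.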

Compound 3, half-maximal inhibitory concentration: > 166000 nM
Compound 3 ended at the assay's limit (the forecaster's own chance of this, stated with the estimate: 65%); the middle value lies beyond the limit too.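

Compound 1 and compound 3 both sit at a limit of this assay, so the step between them cannot be read: the limit of > 166000 nM in this assay, at which 2 of the 3 values shown sit.

The compounds shown leave open whether any group in this place gives a value inside the assay's range, and how compound 1 and compound 3 truly compare.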